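Morpholine to thiomorpholine on the sulfonyl of compound 2

The source may hold more compounds than are shown below. What is called first, only, known or untested is meant among the compounds shown, and "the series" means these compounds.

Three compounds of the series have been run so far, all on the shared core. Compound 1 `CC(O)(C(=O)Nc1ccc(/C(=N\O)c2ccccc2)cc1)C(F)(F)F` gives only a limit in an assay on a protein complex (Cavia porcellus) with sulfonylurea receptors; K-ATP channels (Homo sapiens) as the target (on this read-out higher numbers stand for weaker inhibition and lower numbers for stronger inhibition), namely > 30000 nM. Compound 3 `CC(O)(C(=O)Nc1ccc([C@H](O)c2ccccc2)cc1)C(F)(F)F` likewise gives only a limit in this assay, > 30000 nM. Within the data shown here, compound 2 `CC(O)(C(=O)Nc1ccc(S(=O)(=O)N2CCOCC2)cc1)C(F)(F)F` gives 5850 nM in this assay, the sole number among the three results. Compound 1 and compound 3 together account for (the limit of > 30000 nM in this assay, at which 2 of the 3 values shown sit). Compound 2 therefore stands alone as the measured reference for the next step.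

Compound 4 `CC(O)(C(=O)Nc1ccc(S(=O)(=O)N2CCSCC2)cc1)C(F)(F)F` differs from compound 2 by thiomorpholin-4-yl in place of morpholin-4-yl on a sulfonyl sulfur. Among the measured compounds shown here, no measured pair covers this exchange, so no step size can be drawn from the data; the expectation is a step of no size beyond the scatter, with no preferred direction. For compound 4 the estimated result in this assay is 5500 nM, expected to fall between 2000 nM and 15000 nM. The step expected a 1.1-fold lower number from compound 2 to compound 4 (0.03 log units; within the scatter) is accordingly flat within the usual scatter.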

Compound 4, half-maximal inhibitory concentration: 4580 nM
Beside the measured number, compound 4's estimate is 1.2-fold (0.08 log units) above it; the range from low to high includes it.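

Exchanging morpholin-4-yl for thiomorpholin-4-yl on a sulfonyl sulfur gives, in this assay, a 1.3-fold lower number from compound 2 to compound 4 (0.11 log units; within the scatter) as the first step measured between two compounds of the series that differ in one place. At this position, with this pair, the ring can therefore carry either oxygen or sulfur as its second hetero atom without a difference that can be told from the scatter. Nothing in the data at hand gives a reason for this flat step.

Still open, as far as these compounds go, is how a piperidine, a piperazine or an open-chain diethylamine on the same sulfonyl sulfur would read in this assay, and whether any of them would give a step beyond the scatter. Also open, from the compounds shown here alone, is what a carboxylic acid or a primary amine on the thiomorpholin-4-yl ring would do, starting from compound 4 at 4580 nM in this assay as the reference.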